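Fluoro in Place of Methoxy: Compound 1 to Compound 3

The source may hold more compounds than are shown below. What is called first, only, known or untested is meant among the compounds shown, and "the series" means these compounds.

Compound 1, `COc1ccc(/C=C/S(=O)(=O)Cc2ccc(OC)cc2)cc1`, in a functional assay on DU-145 cells (Homo sapiens) for antiproliferative activity, read by trypan blue exclusion (a lower number here means a stronger inhibitor, a higher number a weaker inhibitor), gives only a limit of the assay, > 20000 nM.
Compound 2, `COc1cc(OC)c(/C=C/S(=O)(=O)Cc2ccc(O)cc2)c(OC)c1`, in this assay gives 7500 nM.

Compound 1 therefore stands at the limit of > 20000 nM in this assay, at which 1 of the 2 values shown sits, with no number of its own. Compound 3, `COc1ccc(CS(=O)(=O)/C=C/c2ccc(F)cc2)cc1`, differs from compound 1 by fluoro in place of methoxy on an aromatic carbon. Among the measured compounds shown here, no measured pair shows this change, so its size is unknown. The expected step from compound 1 is a number no higher from compound 1 to compound 3 (the limit leaves the size open), none beyond the scatter. Compound 3 is estimated at 20000 nM, expected between 8000 nM and 50000 nM.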

Compound 3, half-maximal inhibitory concentration: 1250 nM
Compound 3: the middle estimate sits 16-fold (1.20 log units) above what was measured; the measured number lies below the stated range.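

In this assay, among the compounds shown here, fluoro in place of methoxy on an aromatic carbon gives an at least 16-fold lower number from compound 1 to compound 3 (1.20 log units; beyond the scatter) and thereby shows that the number responds strongly to the group at this position, which the earlier compounds could not show. The step gives only a minimum for the change, because compound 1 stands at a limit of the assay: the limit of > 20000 nM in this assay, at which 1 of the 3 values shown sits.

The compounds shown leave open whether this drop is particular to fluoro, as the effect of chloro, a nitrile or an amine at this position is unknown. On these data alone, whether the same change would give a similar step on another core also remains open.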